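The compounds below may be only part of what the source reports. "The series", "measured", "known", "first", "only" and "open" are said of these compounds alone.

Series notes, antagonism at the receptor.

Compound 1 `C[C@@H]1CN(c2sc(CO)nc2-c2nc3ccccc3[nH]2)CCN1C(=O)Cn1cnc2cccnc21` returns only a limit in a functional assay on U2OS cells for antagonist activity at C-X-C chemokine receptor type 3 (Homo sapiens), read by beta-arrestin recruitment (a higher number here means a weaker inhibitor, a lower number a stronger inhibitor), namely > 10000 nM; one of the three results stands at this limit (the limit of > 10000 nM in this assay, at which 1 of the 3 values shown sits). Compound 2 `CCCc1ncc(-c2nc(C(F)(F)F)sc2N2CCN(C(=O)Cn3cnc4cccnc43)[C@H](C)C2)cn1` gives 33 nM in this assay. Compound 3 `CCOc1ncc(-c2nc(C(F)(F)F)sc2N2CCN(C(=O)Cn3ccc4cnccc43)[C@H](C)C2)cn1` gives 23 nM in this assay, the lowest of the two numbers, with compound 2 its nearest neighbour at a gap that stays within the scatter, so no order between compound 2 and compound 3 can be read from these two results.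

Compound 4 `CCOc1ncc(-c2nc(C(F)(F)F)sc2N2CCN(C(=O)Cn3cc(Cl)cn3)[C@H](C)C2)cn1` has not yet been run in this assay. It differs from compound 3 in one place, on a saturated chain carbon bound to a carbonyl carbon: a group of 6 heavy atoms (3 carbon, 2 nitrogen, 1 chlorine; one five-membered aromatic ring with 2 hetero atoms) in place of a group of 9 heavy atoms (7 carbon, 2 nitrogen; one five-membered aromatic ring with 1 hetero atom, one six-membered aromatic ring with 1 hetero atom), on a saturated chain carbon bound to a carbonyl carbon. Among the compounds with values here, no measured pair in this set walks a single step of this kind, so the expected size rests on the change alone. The expectation is a moderate rise in the number, that is a somewhat weaker inhibitor, though a shift that stays within the scatter cannot be excluded. For compound 4 the estimated value in this assay is 70 nM, with a likely range of 15 nM to 400 nM. The step expected from this estimate is a 3.0-fold higher number from compound 3 to compound 4 (0.48 log units; beyond the scatter), an expectation rather than a measurement.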

Compound 4, half-maximal inhibitory concentration: 272 nM
For compound 4 the middle estimate is 3.9-fold (0.59 log units) below the measured one, within the range that was stated.
By their numbers in this assay, from the lowest: compounds 3 and 2 (each within the scatter of the next); then compound 4. At a limit, above all of these: compound 1.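

Within the data shown here, on the saturated chain carbon bound to a carbonyl carbon, the change to 4-chloro-1H-pyrazol-1-yl gives the first single-place step in this set, and in this assay it reads as a 12-fold higher number from compound 3 to compound 4 (1.07 log units; beyond the scatter) and is large and beyond the scatter. This position is therefore not indifferent to the group it carries, even though the leaving and entering groups have the same counts of hydrogen-bond donors and acceptors and no net charge. Nothing measured here gives a cause for this step.

The compounds shown leave open whether the loss follows from the smaller ring system, the chlorine or the added ring nitrogen. They also do not show how a methyl or nitrile group in place of the chlorine would read at this position.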